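The source may hold more compounds than are shown below. What is called first, only, known or untested is meant among the compounds shown, and "the series" means these compounds.

Measured so far:
- compound 1 `CCCc1ccc(NC(=S)N2CCC(C(O)(c3ccccc3)c3ccccc3)CC2)cc1`: 777 nM
- compound 2 `OC(c1ccccc1)(c1ccccc1)C1CCN(C(=S)Nc2ccc(C(F)(F)F)cc2)CC1`: 178 nM
- compound 3 `COc1ccc(OC(=O)N2CCC(C(O)(c3ccccc3)c3ccccc3)CC2)cc1`: 2680 nM

All three share a core and were tested in a functional assay for antagonist activity at Neuropeptide Y receptor type 2 (Homo sapiens); on this read-out higher numbers stand for weaker inhibition and lower numbers for stronger inhibition. Compound 3 gives the highest number of the three: compound 1 stands closest to it, with a lower number, and compound 2 lies furthest away, with a much lower number still. Among the compounds with values here, the one single-point step among the measured compounds, a 4.4-fold lower number from compound 1 to compound 2 (0.64 log units; beyond the scatter), concerns a trifluoromethyl in place of propyl on an aromatic carbon, a different part of the molecule from the one changed here.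

Compound 4 `CCOc1ccc(OC(=O)N2CCC(C(O)(c3ccccc3)c3ccccc3)CC2)cc1` differs from compound 3 by methyl in place of hydrogen on a saturated chain carbon bound to an oxygen on an aromatic ring. Within the data shown here, no measured pair shows this change or anything close to it, so the step from compound 1 to compound 2 offers no guide to its direction or size. With one carbon added at the far end of a short chain, the expectation is a step no larger than the usual scatter in either direction, a 1.2-fold lower number from compound 3 to compound 4 (0.07 log units; within the scatter). Compound 4 is therefore estimated at 2300 nM, with a range from 900 nM to 6000 nM.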

Compound 4, half-maximal inhibitory concentration: 1580 nM
Beside the measured number, compound 4's estimate is 1.5-fold (0.16 log units) above it; the measured number falls inside the stated range.
By their numbers in this assay, from the lowest: compound 2; then compound 1; then compounds 4 and 3 (each within the scatter of the next).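

Going from methoxy to ethoxy gives a 1.7-fold lower number from compound 3 to compound 4 (0.23 log units; within the scatter) in this assay, so the two compounds cannot be told apart on this read-out. Within the data shown here, this is the first view of this position, and it shows that a methyl in place of hydrogen on the saturated chain carbon bound to the oxygen leaves the number within the normal spread of repeated measurements. Nothing available explains why the number stays within that spread.

From the compounds shown here alone, a single small step cannot show how much room there is at this position, so it remains open whether a longer chain such as propoxy or butoxy would also leave the number unchanged. Equally open, going by these compounds, is what an amine or a carboxylic acid at the end of that chain would do.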